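Adding one fluorine back onto the benzyl ring

The source may report more compounds than this note shows. Statements on the series, on what has been measured and on what is new or still open speak of the compounds shown alone.

Compound 1 `COc1ccc(N2C(=O)N(Cc3c(F)cc(F)cc3F)c3ccccc3S2(=O)=O)cc1OC` in an assay on isolated protein for displacement of a labelled ligand from Orexin/Hypocretin receptor type 1 (Homo sapiens), with a stated time of 90 min (a lower number here means a stronger inhibitor, a higher number a weaker inhibitor), gives 50.1 nM. Compound 3 `COc1cc(N2C(=O)N(Cc3c(F)cc(F)cc3F)c3ccccc3S2(=O)=O)ccn1` gives 398 nM, a change of a 7.9-fold higher number from compound 1 to compound 3 (0.90 log units; beyond the scatter). From the compounds shown here alone, compound 2 `COc1ccc(N2C(=O)N(Cc3ccc(F)cc3Cl)c3ccccc3S2(=O)=O)cc1OC` reaches only a limit of this assay, > 2510 nM, so its true number is unknown (the limit of > 2510 nM in this assay, at which 1 of the 3 values shown sits). That means a loss of an at least 50-fold higher number from compound 1 to compound 2 (1.69 log units; beyond the scatter). Compound 4 `COc1ccc(N2C(=O)N(Cc3c(F)cc(F)cc3Cl)c3ccccc3S2(=O)=O)cc1OC` differs from compound 2 by fluoro in place of hydrogen on an aromatic carbon. Only the large step from compound 1 to compound 2 bears on this, and it suggests that restoring a fluoro may recover part of the loss, so a lower number is expected. Compound 4 is therefore estimated at 500 nM, within 100 nM to 3000 nM, an expected step of an at least 5.0-fold lower number from compound 2 to compound 4 (0.70 log units; beyond the scatter).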

Compound 4, inhibition constant: 25.1 nM
For compound 4 the middle estimate is 20-fold (1.30 log units) above the measured one; measured number below the stated range.
By their numbers in this assay, from the lowest: compounds 4 and 1 (each within the scatter of the next); then compound 3. At a limit, above all of these: compound 2.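

In this assay, a single fluoro on this aromatic carbon, ortho to a large group, makes a very large difference: an at least 100-fold lower number from compound 2 to compound 4 (2.00 log units; beyond the scatter). The value of compound 2 is a limit, not a number: the limit of > 2510 nM in this assay, at which 1 of the 4 values shown sits. Chloro in place of fluoro shows no difference beyond the scatter, a 2.0-fold lower number from compound 1 to compound 4 (0.30 log units; within the scatter), so the loss in compound 2 goes with the missing fluoro, not with the chloro.

From the compounds shown here alone, whether a methyl or a methoxy group at this place would serve as well as fluoro stays open, as does how the 2-chloro-4,6-difluorobenzyl group behaves alongside the 2-methoxypyridin-4-yl group of compound 3.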